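The compounds below may be only part of what the source reports. "The series", "measured", "known", "first", "only" and "open" are said of these compounds alone.

Of the compounds shown here, three have been tested in an assay on isolated protein for displacement of a labelled ligand from metabotropic glutamate receptor 5 (Homo sapiens), with a stated time of 60 min, tested at 1 uM (a lower number here means less inhibition, a higher number more inhibition at the concentration tested (going by the name of the read-out)), and they share one core. Compound 1 `COc1ccc2ncc(S(=O)(=O)c3ccc(OC)c(Cl)c3)c(N3CCC(C)CC3)c2c1` gives 21% in this assay, compound 2 `CC1CCN(c2c(S(=O)(=O)c3cc(F)cc(F)c3)cnc3ccc(Cl)cc23)CC1` gives 93%, and compound 3 `COc1ccc2ncc(S(=O)(=O)c3cc(F)cc(F)c3)c(N3CCC(C)CC3)c2c1` gives 30%. Compound 2 stands highest of the three, with compound 3 nearest and compound 1 furthest, and both gaps are beyond the scatter.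

The unmeasured compound 4 `COc1cccc(S(=O)(=O)c2cnc3ccc(Cl)cc3c2N2CCC(C)CC2)c1` keeps the core of compound 2 and changes only the group on the sulfonyl sulfur: 3-methoxyphenyl in place of 3,5-difluorophenyl on a sulfonyl sulfur

For the measured compounds named here, two measured steps bear on this. The step of a number 63 percentage points lower from compound 2 to compound 3 (beyond the scatter) changes the core itself and is not the change made here; it only shows that the core of compound 2 is the one that carries the high numbers. The step of a number 9 percentage points higher from compound 1 to compound 3 (within the scatter) changes the group on the sulfonyl sulfur, as the step to compound 4 does, and it stays within the scatter. Going by the values given here, since the one swap of this kind that has been measured moved the number little, the step of a number 13 percentage points lower from compound 2 to compound 4 (beyond the scatter) is expected to be small as well, with some room for a drop. Among the compounds with values here, only one such swap has been measured, and the range is kept wide for that reason. Compound 4 is therefore estimated at 80%, within a range of 55% to 95%.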

Compound 4, a percentage reported as inhibition, at one concentration (the size of the read-out at that concentration, not a potency): 87%
For compound 4 the middle estimate is 7 percentage points below the measured one; the measured number falls inside the stated range.
By their numbers in this assay, from the lowest: compounds 1 and 3 (each within the scatter of the next); then compounds 4 and 2 (each within the scatter of the next).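

In this assay, the swap of 3,5-difluorophenyl for 3-methoxyphenyl on a sulfonyl sulfur gives a number 6 percentage points lower from compound 2 to compound 4 (within the scatter) and so leaves the number high on the core of compound 2. For the compounds shown here, the only earlier swap at this place, a number 9 percentage points higher from compound 1 to compound 3 (within the scatter), was seen on a core with low numbers, where a small step says little about whether the group matters; the new step shows that a different aryl group can be carried on the high-number core too, even though the two fluorines leave and a methoxy enters, with 1 hydrogen-bond acceptor in place of 0. Nothing available here explains why the two groups give numbers within the scatter of each other.

The compounds shown carry only substituted phenyl groups on the sulfonyl sulfur, so it remains open whether the number would hold with a phenyl bearing an amine or a carboxylic acid, or with a plain methyl in place of the aromatic ring. From the compounds shown here alone, it also remains open whether 3-methoxyphenyl would behave the same way on the core of compound 3.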